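Methylsulfonyl in place of a smaller sulfur group

This account rests on a few compounds, and the source may have more. Where it says the series, first, only, none or still open, it means among the compounds named here.

In a functional assay on the whole organism for antagonist activity, with Mus musculus as the target (a higher number here means that more compound is needed for the effect, a lower number that less compound is needed), compound 1 `Cn1c(-c2cccc(F)c2)nnc1S(C)(=O)=O` gives > 200 mg/kg, which is a limit of the assay. In this assay compound 2 `Cn1c(-c2ccccc2)nnc1[S+](C)[O-]` gives > 100 mg/kg, also a limit, so compound 2 stands without a number. Compound 3 `Cn1c(-c2ccccc2)nnc1S(C)(=O)=O` follows from compound 2 by one change on an aromatic carbon: a group of 4 heavy atoms (1 carbon, 2 oxygen, 1 sulfur; no ring) in place of a group of 3 heavy atoms (1 carbon, 1 oxygen, 1 sulfur; no ring), on an aromatic carbon. Within the data shown here, no measured step bears on this change, and only these two limits are available. In this assay the expected step, a step that the limit leaves unreadable from compound 2 to compound 3, is small, with no clear direction beyond the scatter. For compound 3 the estimated value is 150 mg/kg, with an expected range of 60 mg/kg to 300 mg/kg.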

Compound 3, dose for half-maximal effect: > 200 mg/kg
Compound 3: no number, only a limit (the forecaster's own chance of this, stated with the estimate: 60%); at least 1.3-fold (0.12 log units) between middle value and limit.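

Compound 1, compound 2 and compound 3 give only limits in this assay; neither the step from compound 2 to compound 3 nor that from compound 1 to compound 3 can be read. The compounds shown leave open whether methylsulfonyl or fluoro shifts the dose for half-maximal effect at all.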